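Thiophen-3-yl for phenyl: cytotoxicity notes on four compounds

The source may hold more compounds than are shown below. What is called first, only, known or untested is meant among the compounds shown, and "the series" means these compounds.

Measured so far:
compound 1, `Oc1cccc(-c2cc(-c3ccccc3)nc(-c3ccccc3Cl)c2)c1`: 2930 nM
compound 2, `Oc1ccc(-c2cc(-c3ccsc3)nc(-c3cccc(Cl)c3)c2)cc1`: 5760 nM
compound 3, `Oc1ccc(-c2cc(-c3ccccc3)nc(-c3cccc(Cl)c3)c2)cc1`: 6100 nM

In a functional assay on HCT-15 cells (Homo sapiens) for cytotoxicity, read by CCK-8 assay and cell counting, with a stated time of 2 days (on this read-out lower numbers stand for stronger inhibition and higher numbers for weaker inhibition), compound 1 gives the lowest of the three numbers; its gap to compound 2 lies within the scatter, its gap to compound 3 just beyond it. Compound 2 and compound 3 differ in one place only: thiophen-3-yl in place of phenyl on an aromatic carbon. In this assay this change gave a 1.1-fold lower number from compound 3 to compound 2 (0.02 log units; within the scatter), so on this pair it is neutral. Compound 1 and compound 3 are built from the same atoms joined differently; the difference between the two cores is not broken down here.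

Compound 4, `Oc1cccc(-c2cc(-c3ccsc3)nc(-c3ccccc3Cl)c2)c1`, is not yet measured. It differs from compound 1 by thiophen-3-yl in place of phenyl on an aromatic carbon. This is the same kind of change as from compound 3 to compound 2, not the same one: around the place, compound 1 carries a 2-chlorophenyl group and a 3-hydroxyphenyl group where compound 3 carries a 3-chlorophenyl group and a 4-hydroxyphenyl group.

For compound 4 the expected step is a 1.0-fold lower number from compound 1 to compound 4 (0.02 log units; within the scatter), a near-neutral step, because the like change gave a 1.1-fold lower number from compound 3 to compound 2 (0.02 log units; within the scatter). For compound 4 the estimate in this assay is 2800 nM. For compound 4 the expected range runs from 1200 nM to 6500 nM, widened for the differing surroundings of the place.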

Compound 4, half-maximal inhibitory concentration: 2500 nM
Compound 4: the middle estimate sits 1.1-fold (0.05 log units) above what was measured; the measured number falls inside the stated range.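

In this assay, thiophen-3-yl in place of phenyl on an aromatic carbon gave a 1.2-fold lower number from compound 1 to compound 4 (0.07 log units; within the scatter), so the change is also neutral on the core of compound 1, where the place carries a 2-chlorophenyl group and a 3-hydroxyphenyl group around it. Set side by side, the two steps do not differ, and the neutral result carries across both cores: the same change on two cores in this assay, a 1.1-fold lower number (0.02 log units; within the scatter) from compound 3 to compound 2 and a 1.2-fold lower number (0.07 log units; within the scatter) from compound 1 to compound 4, 1.1-fold (0.04 log units) apart, within the scatter of two such steps. This shows only that phenyl and thiophen-3-yl can stand in for each other on these two cores in this one cell read-out; with just two pairs, it does not show that the same would hold on a core with other substituents, or that the two groups are interchangeable in any other test.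

The compounds shown hold only these two rings at this place, so it remains open whether a smaller or larger replacement, such as a methyl group, a furan-3-yl ring, or a phenyl ring carrying an amine or a carboxylic acid, would move the number at all. Also open, going by these compounds, is what happens when the hydroxyl is replaced by methoxy or the chlorine by fluorine on either core.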